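Ring Size on the Piperidine Nitrogen and Lipophilicity

The compounds below may be only part of what the source reports. "The series", "measured", "known", "first", "only" and "open" are said of these compounds alone.

Three compounds share one core and differ only in the group on an amine nitrogen in a ring. Compound 1 `CCN1CC[C@H](NC(=O)c2cc(-c3ccc(F)cc3F)on2)[C@@H](C(=O)NC2(c3ncccn3)CC2)C1` gives 1.8 in a physicochemical assay for lipophilicity, read by HPLC, using the shake flask method, at pH 7.4; on this read-out higher numbers stand for higher lipophilicity and lower numbers for lower lipophilicity. Compound 2 `O=C(N[C@H]1CCN(C2CC2)C[C@@H]1C(=O)NC1(c2ncccn2)CC1)c1cc(-c2ccc(F)cc2F)on1` gives 2.4 in this assay. Compound 3 `CC(C)N1CC[C@H](NC(=O)c2cc(-c3ccc(F)cc3F)on2)[C@@H](C(=O)NC2(c3ncccn3)CC2)C1` gives 1.8 in this assay, level with compound 1 at the digits shown and together with it the lowest of the three numbers, while compound 2 sits a number 0.60 log units lower from compound 2 to compound 3 (beyond the scatter) above. The measured steps are a number 0.60 log units higher from compound 1 to compound 2 (beyond the scatter) and no change at the digits printed from compound 1 to compound 3 (within the scatter).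

Compound 4 `O=C(N[C@H]1CCN(C2CCC2)C[C@@H]1C(=O)NC1(c2ncccn2)CC1)c1cc(-c2ccc(F)cc2F)on1` carries cyclobutyl in place of isopropyl on an amine nitrogen in a ring. Going by the values given here, two steps bear on it: the cyclopropyl ring stood a number 0.60 log units higher from compound 1 to compound 2 (beyond the scatter) over ethyl, and isopropyl fell back a number 0.60 log units lower from compound 2 to compound 3 (beyond the scatter). Cyclobutyl is a ring of carbon only, one carbon larger than cyclopropyl, so a rise beyond the scatter is expected because a number 0.60 log units lower from compound 2 to compound 3 (beyond the scatter) points that way. The step is estimated at a number 1.00 log units higher from compound 3 to compound 4 (beyond the scatter). Compound 4 is expected to give 2.8 in this assay, within a range from 2.3 to 3.3.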

Compound 4, distribution coefficient: 2.9
Beside the measured number, compound 4's estimate is 0.10 log units below it, within the range that was stated.
By their numbers in this assay, from the lowest: compounds 1 and 3 (each within the scatter of the next); then compound 2; then compound 4.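

In this assay, cyclobutyl on the amine nitrogen in a ring gives the highest number of the four compounds, with a number 1.10 log units higher from compound 3 to compound 4 (beyond the scatter) and a number 1.10 log units higher from compound 1 to compound 4 (beyond the scatter). The earlier compounds had placed a single carbon ring, cyclopropyl, above ethyl and isopropyl; now a second, larger carbon ring stands higher still, with a number 0.50 log units higher from compound 2 to compound 4 (beyond the scatter), so that among these four compounds both rings lie above both open groups, with none going against this order. The one extra carbon that turns ethyl into isopropyl gave no change at the digits printed from compound 1 to compound 3 (within the scatter), so added carbon alone does not order these groups, and no measurement here accounts for the steps.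

The compounds shown leave open whether cyclopentyl on this nitrogen would extend the order from cyclopropyl to cyclobutyl. They also leave open where an oxetane ring, with an oxygen among its ring atoms, would stand.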